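Urea side chain changes on the shared quinazoline-free core

The source may report more compounds than this note shows. Statements on the series, on what has been measured and on what is new or still open speak of the compounds shown alone.

Numbers in a functional assay on A-431 cells (Homo sapiens) for antiproliferative activity, read by sulforhodamine B assay, with a stated time of 72 h (on this read-out lower numbers stand for stronger inhibition and higher numbers for weaker inhibition), so far:
compound 1 `CS(=O)(=O)CCNC(=O)Nc1cc2c(Nc3ccc(F)c(Cl)c3)ncnc2cc1O[C@H]1CCOC1` gives 1570 nM
compound 2 `CN(C)CCCNC(=O)Nc1cc2c(Nc3ccc(F)c(Cl)c3)ncnc2cc1O[C@H]1CCOC1` gives 226 nM
compound 3 `O=C(Nc1cc2c(Nc3ccc(F)c(Cl)c3)ncnc2cc1O[C@H]1CCOC1)N1CC(O)C1` gives 1930 nM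

Compound 3 gives the highest number of the three. One of its gaps lies within the scatter, so those two compounds cannot be separated: a 1.2-fold higher number from compound 1 to compound 3 (0.09 log units; within the scatter). The other gap is clear: an 8.5-fold higher number from compound 2 to compound 3 (0.93 log units; beyond the scatter). Compound 4 `O=C(Nc1cc2c(Nc3ccc(F)c(Cl)c3)ncnc2cc1O[C@H]1CCOC1)N1CCC(N2CCCC2)CC1` differs from compound 3 in one place: 4-(pyrrolidin-1-yl)piperidin-1-yl in place of 3-hydroxyazetidin-1-yl on a carbonyl carbon. For the measured compounds named here, the steps that bear on this are the two that swap the (3-(dimethylamino)propyl)amino chain in or out: a 6.9-fold lower number from compound 1 to compound 2 (0.84 log units; beyond the scatter) and an 8.5-fold higher number from compound 2 to compound 3 (0.93 log units; beyond the scatter). Both say that the urea substituent carrying a dimethylamino group goes with a markedly lower number in this assay, while the methylsulfonyl chain of compound 1 and the 3-hydroxyazetidin-1-yl group of compound 3 sit together at the high end. The entering 4-(pyrrolidin-1-yl)piperidin-1-yl group likewise brings a second nitrogen, so a downward step of comparable size is expected, a 5.5-fold lower number from compound 3 to compound 4 (0.74 log units; beyond the scatter). Compound 4 is therefore estimated to give 350 nM in this assay, within 120 nM to 1100 nM.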

Compound 4, half-maximal inhibitory concentration: 317 nM
The estimate for compound 4 lay 1.1-fold (0.04 log units) above the measured number, within the range that was stated.
By their numbers in this assay, from the lowest: compounds 2 and 4 (each within the scatter of the next); then compounds 1 and 3 (each within the scatter of the next).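

At this carbonyl carbon in this assay, 4-(pyrrolidin-1-yl)piperidin-1-yl gives a 6.1-fold lower number from compound 3 to compound 4 (0.78 log units; beyond the scatter) and a 5.0-fold lower number from compound 1 to compound 4 (0.69 log units; beyond the scatter), so a low number here is not confined to the open (3-(dimethylamino)propyl)amino chain of compound 2. For the compounds shown here, that chain and the ring group, which has no hydrogen-bond donor, cannot be separated, with a 1.4-fold higher number from compound 2 to compound 4 (0.15 log units; within the scatter); across the four compounds, the two groups carrying an amine stand apart from the methylsulfonyl chain of compound 1 and the 3-hydroxyazetidin-1-yl group of compound 3, and no compound here goes against this. No measurement available here explains these steps.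

As far as these compounds go, whether the pyrrolidine ring is needed remains open, as a plain piperidin-1-yl group would test that. A morpholin-4-yl group, a 4-methylpiperazin-1-yl group or a carboxylic acid at this carbonyl carbon is also left unresolved.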